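Azide to Triazole: Expected Shift in Cell Cytotoxicity

The source may report more compounds than this note shows. Statements on the series, on what has been measured and on what is new or still open speak of the compounds shown alone.

Three compounds share one core and differ only in the group on the saturated chain carbon bound to an aromatic carbon. In a functional assay on HeLa cells (Homo sapiens) for cytotoxicity, read by MTT assay, with a stated time of 72 h (a lower number here means a stronger inhibitor, a higher number a weaker inhibitor), compound 1 `NS(=O)(=O)c1cc(-c2nnc(CN3CCC(Cc4ccccc4)CC3)o2)c(Cl)cc1SCc1ccccc1` gives 16000 nM. Compound 2 `NS(=O)(=O)c1cc(-c2nnc(CN3CCN(c4ccc(Cl)cc4)CC3)o2)c(Cl)cc1SCc1ccccc1` gives 11000 nM in this assay. Compound 3 `[N-]=[N+]=NCc1nnc(-c2cc(S(N)(=O)=O)c(SCc3ccccc3)cc2Cl)o1` gives 115000 nM, the highest of the three numbers; compound 1 stands nearest to it and compound 2 furthest, and both gaps lie beyond the scatter.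

Compound 4 `NC(=O)c1cn(Cc2nnc(-c3cc(S(N)(=O)=O)c(SCc4ccccc4)cc3Cl)o2)nn1` has not yet been measured. It differs from compound 3 in that (4-carbamoyl-1H-1,2,3-triazol-1-yl in place of azido on a saturated chain carbon bound to an aromatic carbon). Among the measured compounds shown here, no measured pair shows this exact change, so the size of the step is open. Compounds 1 and 2, which carry other groups on that saturated chain carbon, both give lower numbers than compound 3, so a step toward a lower number, of moderate size, is expected. The expected step is a 2.9-fold lower number from compound 3 to compound 4 (0.46 log units; beyond the scatter). Compound 4 is estimated at 40000 nM, with a range from 12000 nM to 130000 nM.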

Compound 4, half-maximal inhibitory concentration: 75000 nM
For compound 4 the middle estimate is 1.9-fold (0.27 log units) below the measured one, and the stated range covers the measured number.
By their numbers in this assay, from the lowest: compounds 2 and 1 (each within the scatter of the next); then compounds 4 and 3 (each within the scatter of the next).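

In this assay the exchange gives a 1.5-fold lower number from compound 3 to compound 4 (0.19 log units; within the scatter), so on this saturated chain carbon bound to an aromatic carbon, 4-carbamoyl-1H-1,2,3-triazol-1-yl reads the same as azido, even though it brings a five-membered aromatic ring and a hydrogen-bond donor. A larger group with a ring at this place therefore does not by itself give numbers like those of compound 1 at 16000 nM and compound 2 at 11000 nM. Nothing available here explains why the step stays within the scatter.

The compounds shown leave open whether the carbamoyl contributes at all, which an unsubstituted triazole or one carrying a carboxylic acid could test. They also leave open which part of the groups in compound 1 and compound 2 goes with their lower numbers, a question that a simple amine on the same carbon could begin to answer.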